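Swapping the Alkoxy Pyridine for a Thioether Pyridine

This account rests on a few compounds, and the source may have more. Where it says the series, first, only, none or still open, it means among the compounds named here.

Measured so far:
- Compound 1 `COc1cc([C@](O)(CCN(C)C)[C@@H](c2cc3cc(Br)ccc3nc2OC)c2cccc(OC)c2F)cc(OC(C)C)n1`: 6 uL/min
- Compound 2 `COc1cc([C@](O)(CCN(C)C)[C@@H](c2cc3cc(Br)ccc3nc2OC)c2ccnc(OC)c2OC)cc(OC(C)C)n1`: 6.7 uL/min
- Compound 3 `CCOc1cc([C@](O)(CCN(C)C)[C@@H](c2cc3cc(Br)ccc3nc2OC)c2ccnc(OC)c2OC)cc(OC(C)C)n1`: 1.6 uL/min

In an ADME assay on microsomes from liver (Mus musculus) for metabolic stability (on this read-out higher numbers stand for fast clearance and lower numbers for slow clearance), compound 1 stands second highest of the three numbers. Compound 2 sits nearest, with a 1.1-fold higher number from compound 1 to compound 2 (0.05 log units; within the scatter), a gap within the scatter. Compound 3 lies furthest; its value shows a clearly lower number than compound 1.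

Compound 4 `COc1cccc([C@H](c2cc3cc(Br)ccc3nc2OC)[C@@](O)(CCN(C)C)c2cc(SC)nc(SC)c2)c1F` has not been measured. It differs from compound 1 in this way: a group of 10 heavy atoms (7 carbon, 1 nitrogen, 2 sulfur; one six-membered aromatic ring with 1 hetero atom) in place of a group of 12 heavy atoms (9 carbon, 1 nitrogen, 2 oxygen; one six-membered aromatic ring with 1 hetero atom), on a saturated chain carbon bound to an oxygen on a saturated carbon and two saturated chain carbons

Neither measured step touches this part of the molecule. The step of a 1.1-fold higher number from compound 1 to compound 2 (0.05 log units; within the scatter) changed the aryl group on the neighbouring chain carbon and stayed within the scatter. The step of a 4.2-fold lower number from compound 2 to compound 3 (0.62 log units; beyond the scatter) changed a methyl on an alkoxy substituent of the same ring that is swapped here, and moved the number modestly. So substituents on this ring can matter, but nothing directly tells how the entering group will behave.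

Compound 4 is therefore estimated at 9 uL/min, expected between 3 uL/min and 27 uL/min, a step of a 1.5-fold higher number from compound 1 to compound 4 (0.18 log units; within the scatter) with wide uncertainty.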

Compound 4, intrinsic clearance in a liver preparation (reported as CLH), per the amount of preparation that the assay uses: 17 uL/min
Compound 4: middle estimate off by 1.9-fold (0.28 log units), on the low side; low and high end bracket the measured number.
By their numbers in this assay, from the lowest: compound 3; then compounds 1 and 2 (each within the scatter of the next); then compound 4.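

Of the steps shown, only this one replaces the whole ring group on the saturated chain carbon bound to an oxygen on a saturated carbon and two saturated chain carbons, and in this assay it gives a 2.8-fold higher number from compound 1 to compound 4 (0.45 log units; beyond the scatter). The group that enters and the group that leaves have the same counts of hydrogen-bond donors and acceptors and no net charge, so these counts alone do not separate the two groups, even though the number moved. Nothing measured here gives a reason for the shift.

The entering group differs from the leaving one in several atoms at once, so the compounds shown leave open whether the sulfur atoms or the smaller carbon count accounts for the step. They also leave open how a ring carrying one sulfur substituent and one oxygen substituent, or a ring bearing an amine or a nitrile, would read in this assay.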